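Replacing Methylsulfonyl with Acetyl on the Bromophenyl Arm

The compounds below may be only part of what the source reports. "The series", "measured", "known", "first", "only" and "open" are said of these compounds alone.

Among three measured analogues of one shared core, compound 3 `CCCCN(CC)c1nc(C)nc2c1nnn2-c1ccc(S(C)(=O)=O)cc1Br` stands at the highest number: in an in vitro assay on 293-EBNA cells for binding affinity to corticotropin-releasing factor receptor 1 (Homo sapiens) (a lower number here means a stronger inhibitor, a higher number a weaker inhibitor), compound 3 gives 100 nM. Compound 1 `CCCCN(CC)c1nc(C)nc2c1nnn2-c1ccc(C(C)C)cc1Br` gives 7.5 nM and compound 2 `CCCCN(CC)c1nc(C)nc2c1nnn2-c1ccc(SC)cc1Br` gives 10.6 nM in this assay. Compound 4 `CCCCN(CC)c1nc(C)nc2c1nnn2-c1ccc(C(C)=O)cc1Br` carries acetyl in place of methylsulfonyl on an aromatic carbon. For the measured compounds named here, the steps that bear on this change are a 13-fold higher number from compound 1 to compound 3 (1.12 log units; beyond the scatter) and a 9.4-fold higher number from compound 2 to compound 3 (0.97 log units; beyond the scatter), both beyond the scatter, so moving away from methylsulfonyl is expected to bring the number down, though no acetyl analogue has been measured and the size is uncertain. Compound 4 is therefore estimated at 40 nM, with a range from 12 nM to 130 nM. That estimate means an expected step of a 2.5-fold lower number from compound 3 to compound 4 (0.40 log units; beyond the scatter) in this assay.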

Compound 4, inhibition constant: 33.7 nM
For compound 4 the middle estimate is 1.2-fold (0.07 log units) above the measured one, and the stated range covers the measured number.
By their numbers in this assay, from the lowest: compounds 1 and 2 (each within the scatter of the next); then compound 4; then compound 3.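

Acetyl recovers part of the loss seen with methylsulfonyl in this assay (a 3.0-fold lower number from compound 3 to compound 4 (0.47 log units; beyond the scatter)), but it does not reach the level of methylsulfanyl (a 3.2-fold higher number from compound 2 to compound 4 (0.50 log units; beyond the scatter)) or isopropyl (a 4.5-fold higher number from compound 1 to compound 4 (0.65 log units; beyond the scatter)). The four groups at this position therefore fall on three separate levels, with acetyl on a middle level of its own. Nothing shown here gives a reason for this order.

As far as these compounds go, whether an amine, a carboxylic acid or a longer chain at this position would stay close to compound 1 or fall nearer compound 3 remains open.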